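The compounds below may be only part of what the source reports. "The series", "measured", "known", "first", "only" and "open" are said of these compounds alone.

Measured compounds in a functional assay on CHO cells for agonist activity at Orexin/Hypocretin receptor type 1 (Homo sapiens); a higher number here means that more compound is needed for the effect, a lower number that less compound is needed:
compound 1 `COc1cccc(C(=O)Nc2cccc3ccc(NS(=O)(=O)c4cc(-c5cccc(C(=O)N(C)C)c5)ccc4OC)cc23)c1` gives 473 nM
compound 2 `COc1cccc(C(=O)N(C)c2cccc3ccc(NS(=O)(=O)c4cc(-c5cccc(C(=O)N(C)C)c5)ccc4OC)cc23)c1` gives 232 nM
compound 3 `COc1ccc(C(=O)N(C)c2cccc3ccc(NS(=O)(=O)c4cc(-c5cccc(C(=O)N(C)C)c5)ccc4OC)cc23)cc1` gives 654 nM

Compound 1 sits second highest of the three numbers in this assay. Its nearest neighbour is compound 3, and that gap, a 1.4-fold higher number from compound 1 to compound 3 (0.14 log units; within the scatter), lies within the scatter. Its furthest is compound 2: the step of a 2.0-fold lower number from compound 1 to compound 2 (0.31 log units; beyond the scatter) goes beyond the scatter. Between the two amide variants, a 2.8-fold higher number from compound 2 to compound 3 (0.45 log units; beyond the scatter) also goes beyond the scatter.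

Compound 4 `COc1cccc(C(=O)Nc2c(C)ccc3ccc(NS(=O)(=O)c4cc(-c5cccc(C(=O)N(C)C)c5)ccc4OC)cc23)c1` is the next compound to be measured. It differs from compound 1 by methyl in place of hydrogen on an aromatic carbon. Going by the values given here, none of the three measured steps places a methyl on the shared core, so no step bears on this change directly. Among the compounds with values here, the only measured step that touches the same amide region is a 2.0-fold lower number from compound 1 to compound 2 (0.31 log units; beyond the scatter), a methyl on the amide nitrogen rather than on the ring carbon, and it was modest in size. With nothing closer to lean on, the expected step in this assay from compound 1 to compound 4 is small, with no clear direction, and likely within the scatter; the estimate is a 1.1-fold lower number from compound 1 to compound 4 (0.05 log units; within the scatter). Compound 4 is therefore expected to give about 420 nM in this assay, with a range from 150 nM to 1200 nM.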

Compound 4, half-maximal effective concentration: 148 nM
Compound 4: the middle estimate sits 2.8-fold (0.45 log units) above what was measured; measured number outside the range, below it.
By their numbers in this assay, from the lowest: compounds 4 and 2 (each within the scatter of the next); then compounds 1 and 3 (each within the scatter of the next).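

In this assay, going by these compounds alone, a methyl on the aromatic carbon ortho to the ((3-methoxyphenyl)carbonyl)amino group gives a 3.2-fold lower number from compound 1 to compound 4 (0.50 log units; beyond the scatter), which shows that this position on the shared core, untouched in the earlier compounds, is sensitive to substitution. Alongside a 2.0-fold lower number from compound 1 to compound 2 (0.31 log units; beyond the scatter), the new step shows that a methyl on either the ring carbon or the amide nitrogen lowers the number relative to compound 1, so this effect is not confined to the amide nitrogen, although these two steps are the only evidence for it. Nothing available explains why the methyl on this ring carbon has this effect.

From the compounds shown here alone, it remains open whether another group at this carbon, such as ethyl, fluorine, methoxy or an amine, would shift the number in the same direction, or whether the step depends on methyl itself. Going by these compounds, it is also open whether the ring methyl and the amide nitrogen methyl would add up when carried together in one compound, and whether the ring methyl would have a similar effect alongside the 4-methoxyphenyl group of compound 3.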